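A few compounds are considered here, and "the series" means these few. Any claim that something is new, unique, unknown or untested is made for them only; others in the source may bear on it.

Compound 1 `SC1=NC(n2nc(-c3ccccc3)nc2-c2ccccc2)=CC(c2ccc(Cl)cc2)N1` gives 30 mg/kg in a functional assay on the whole organism with Mus musculus as the target, in the maximal electroshock model, with a stated time of 0.5 h; on this read-out lower numbers stand for an effect already at smaller amounts and higher numbers for an effect only at larger amounts of compound. Compound 2 `SC1=NC(n2nc(-c3ccccc3)nc2-c2ccccc2)=CC(c2ccccc2Cl)N1` gives 30 mg/kg in this assay. Compound 3 `COc1ccc(C2C=C(n3cc(-c4ccccc4)nc3-c3ccccc3)N=C(S)N2)cc1` gives 100 mg/kg in this assay.

Compound 2 stands level with compound 1 at the digits shown, and the two together hold the lowest numbers of the three. For the measured compounds named here, compound 3, which carries a methoxyphenyl group on the saturated ring carbon, lies further off, with a higher number that is beyond the usual scatter; no single step links it to compound 2, so only the two values can be compared.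

Compound 4 `SC1=NC(n2nc(-c3ccccc3)nc2-c2ccccc2)=CC(c2ccc(-c3ccccc3)cc2)N1` differs from compound 2 in one place: 4-phenylphenyl in place of 2-chlorophenyl on a saturated ring carbon. Going by the values given here, the only measured step at this position, no change at the digits printed from compound 1 to compound 2 (within the scatter), shows that moving the chlorine around the ring left the number unchanged within the scatter. The new group is larger than either chlorophenyl, and the values of compound 3 show that a different group at this carbon can raise the number. A small step upward, perhaps within the scatter, is therefore expected in this assay.

Compound 4 is expected to give 60 mg/kg, with a likely range from 30 mg/kg to 150 mg/kg. The expected step is a 2.0-fold higher number from compound 2 to compound 4 (0.30 log units; within the scatter).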

Compound 4, minimum effective dose: 100 mg/kg
Estimate against measurement, compound 4: 1.7-fold (0.22 log units) below; the range from low to high includes it.
By their numbers in this assay, from the lowest: compounds 1 and 2 (each within the scatter of the next); then compounds 3 and 4 (each within the scatter of the next).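

In this assay the earlier step, no change at the digits printed from compound 1 to compound 2 (within the scatter), showed only that moving the chlorine around the ring left the number where it was. The new result shows that this saturated ring carbon is not indifferent to what it carries, with a 3.3-fold higher number from compound 2 to compound 4 (0.52 log units; beyond the scatter) and also a 3.3-fold higher number from compound 1 to compound 4 (0.52 log units; beyond the scatter), both modest but beyond the scatter. Compound 1 and compound 4 differ only by phenyl in place of chloro on an aromatic carbon, so this single swap at the far end of the group is enough to go with a higher dose requirement, though nothing available gives a reason for the rise.

As far as these compounds go, it remains open whether the higher number goes with the added aromatic ring itself or would also appear with other replacements for the chloro, such as a methyl, a methoxy, an amine or a carboxylic acid. Compound 3 differs from the others in more than one place, so it cannot settle this question, and an unsubstituted phenyl on the shared core would be the natural reference point for all of these comparisons.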